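A few compounds are considered here, and "the series" means these few. Any claim that something is new, unique, unknown or untested is made for them only; others in the source may bear on it.

Measured so far in an ADME assay on L929 cells (Mus musculus) for cytotoxicity, read by resazurin assay, with a stated time of 72 h; on this read-out higher numbers stand for weaker inhibition and lower numbers for stronger inhibition:

compound 1 `O=C(/C=C/c1ccc2c(c1)B(O)OC2)c1ccc(Br)cc1` — compound 1 gives > 10 ug/mL, which is a limit of the assay and not a number.
compound 2 `Nc1cccc(C(=O)/C=C/c2ccc3c(c2)B(O)OC3)c1` — compound 2 gives 10 ug/mL.
compound 3 `O=C(/C=C/c1ccc2c(c1)B(O)OC2)c1ccccc1O` — compound 3 gives > 10 ug/mL, again a limit of the assay and not a number.

Compound 1 therefore stands only as a limit; it sits where two of the three values sit, namely (the limit of > 10 ug/mL in this assay, at which 2 of the 3 values shown sit). The pair to follow is compound 1 against compound 4 `CCOC(=O)c1ccc(C(=O)/C=C/c2ccc3c(c2)B(O)OC3)cc1`, which differs by ethoxycarbonyl in place of bromo on an aromatic carbon.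

Of the measured steps, those that leave compound 1 are a number no higher from compound 1 to compound 2 (the limit leaves the size open) and a step that the two limits leave unreadable from compound 1 to compound 3; neither has a readable size, and a number no lower from compound 2 to compound 3 (the limit leaves the size open) also leaves the size open. Within the data shown here, none of them exchanges the bromo for an ethoxycarbonyl, so no measured step speaks directly to the present change. All three measured compounds sit at or near the same level, and nothing among them points to a step beyond the scatter in this assay in either direction.

Compound 4 is thus expected to give about 10 ug/mL, from 5 ug/mL to 30 ug/mL, most likely reported again as a limit. The expected step is a number no higher from compound 1 to compound 4 (the limit leaves the size open), not beyond the scatter.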

Compound 4, half-maximal inhibitory concentration: > 10 ug/mL
Compound 4 ended at the assay's limit (the forecaster's own chance of this, stated with the estimate: 65%); the middle value lies on the limit itself.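

In this assay compound 4 gives > 10 ug/mL, a limit of the assay and not a number. Among these compounds, compound 1 also stands only as a limit, and no step between compound 1 and compound 4 can be read. The compounds shown leave open whether ethoxycarbonyl in place of bromo shifts the read-out at all.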